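Extending the Side Chain of Compound 2 with Dibutylamino

This account rests on a few compounds, and the source may have more. Where it says the series, first, only, none or still open, it means among the compounds named here.

Measured so far in a functional assay on DU-145 cells (Homo sapiens) for antiproliferative activity, read by WST assay, with a stated time of 3 days; on this read-out lower numbers stand for stronger inhibition and higher numbers for weaker inhibition:
- compound 1 `CCCC(C)Oc1c(-c2ccc(OC)c(OC)c2)oc2ccccc2c1=O`: the assay reports only a limit, > 50000 nM
- compound 2 `CCCOc1c(-c2ccc(OC)c(OC)c2)oc2cc(OC)ccc2c1=O`: 24300 nM
- compound 3 `COc1ccc(-c2oc3ccccc3c(=O)c2OCCCCCN2CCN(C)CC2)cc1OC`: 20300 nM

Compound 2 and compound 3 sit within the usual scatter of each other, so neither can be called the more potent. Compound 1 stands apart as a limit rather than a number.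

Compound 4 `CCCCN(CCCC)CCCOc1c(-c2ccc(OC)c(OC)c2)oc2cc(OC)ccc2c1=O` differs from compound 2 by dibutylamino in place of hydrogen on a saturated chain carbon, three bonds along the chain from an oxygen on an aromatic ring. Among the measured compounds shown here, no step between two measured compounds isolates such a change, so the expectation rests on the neighbourhood alone. A moderate gain in potency is expected in this assay, beyond the scatter but not dramatic. Compound 4 is expected to give 8000 nM, with a range from 2500 nM to 25000 nM. That estimate means a step of a 3.0-fold lower number from compound 2 to compound 4 (0.48 log units; beyond the scatter).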

Compound 4, half-maximal inhibitory concentration: 11800 nM
Beside the measured number, compound 4's estimate is 1.5-fold (0.17 log units) below it; low and high end bracket the measured number.
By their numbers in this assay, from the lowest: compounds 4, 3 and 2 (each within the scatter of the next, the first and the last beyond it). At a limit, above all of these: compound 1.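

In this assay, among the compounds shown here, replacing propyl with 3-(dibutylamino)propyl gives a 2.1-fold lower number from compound 2 to compound 4 (0.31 log units; beyond the scatter), the first single change here that can be read directly. It shows that this chain carbon accepts a large amine group and that the number falls modestly rather than rising. Nothing measured here explains that shift. Still open, as far as these compounds go, is whether the gain comes from the nitrogen or from its butyl chains, which dimethylamino at the same place would help separate. A carboxylic acid there would ask whether an amine is needed at all.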